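This account rests on a few compounds, and the source may have more. Where it says the series, first, only, none or still open, it means among the compounds named here.

Measured in a functional assay on DU-145 cells (Homo sapiens) for cytotoxicity, read by trypan blue exclusion, with a stated time of 96 h; a higher number here means a weaker inhibitor, a lower number a stronger inhibitor:
- compound 1 `COc1ccc(CS(=O)(=O)/C=C/c2c(OC)cccc2OC)cc1[N+](=O)[O-]`: 20000 nM
- compound 2 `COc1cc(OC)c(/C=C/S(=O)(=O)Cc2ccc(OC)c([N+](=O)[O-])c2)c(OC)c1`: 2500 nM
- compound 3 `COc1cc(OC)c(/C=C/S(=O)(=O)Cc2ccc(F)c([N+](=O)[O-])c2)c(OC)c1`: 25000 nM

Of these three, compound 2 gives the lowest number, at 2500 nM. Compound 4 `COC(=O)C(Nc1cc(CS(=O)(=O)/C=C/c2c(OC)cc(OC)cc2OC)ccc1OC)c1ccccc1` differs from it at the nitro position, ortho to a methoxy group: a group of 12 heavy atoms (9 carbon, 1 nitrogen, 2 oxygen; one six-membered aromatic ring of carbon only) in place of a group of 3 heavy atoms (1 nitrogen, 2 oxygen; no ring), on an aromatic carbon.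

For the measured compounds named here, no measured step replaces the nitro group, so two steps bear on this change only indirectly. Methoxy in place of hydrogen gave an 8.0-fold lower number from compound 1 to compound 2 (0.90 log units; beyond the scatter), and fluoro in place of methoxy gave a 10-fold higher number from compound 2 to compound 3 (1.00 log units; beyond the scatter). Both are modest, so a modest step is expected in this assay, with its direction poorly defined and only tentatively towards a lower number.

The expected step is a 2.5-fold lower number from compound 2 to compound 4 (0.40 log units; beyond the scatter). For compound 4 the estimated value is 1000 nM, with an expected range of 100 nM to 10000 nM.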

Compound 4, half-maximal inhibitory concentration: 75 nM
Estimate against measurement, compound 4: 13-fold (1.12 log units) above; measured number below the stated range.
By their numbers in this assay, from the lowest: compound 4; then compound 2; then compounds 1 and 3 (each within the scatter of the next).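

In this assay, the first change shown at this position replaces the nitro group with a much larger group bearing an aromatic ring, and it gives a 33-fold lower number from compound 2 to compound 4 (1.52 log units; beyond the scatter). This step is larger than either earlier step, so among these compounds the nitro group is not needed for a low number and this position accepts a far bigger group. Nothing available explains the gain.

The compounds shown leave open which part of the entering group matters. A plain amine or a carboxylic acid on this aromatic carbon would help to separate those parts.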